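A few compounds are considered here, and "the series" means these few. Any claim that something is new, unique, unknown or untested is made for them only; others in the source may bear on it.

Compound 1 `COc1ccc(-n2c(SCC(=O)c3ccc4ccccc4c3)nnc2-c2cc(OC)c(OC)c(OC)c2)cc1`: in a functional assay on PC-3 cells (Homo sapiens) for inhibition, read by MTT assay, with a stated time of 48 h (on this read-out higher numbers stand for weaker inhibition and lower numbers for stronger inhibition), compound 1 gives > 60000 nM, which is a limit of the assay and not a number.
Compound 2 `COc1ccc(-n2c(SCC(=O)C3CC3)nnc2-c2cc(OC)c(OC)c(OC)c2)cc1`: in this assay compound 2 gives 37200 nM.
Compound 3 `COc1cc(-c2nnc(SCC(=O)c3ccc4ccccc4c3)n2-c2ccc(N(C)C)cc2)cc(OC)c1OC`: in this assay compound 3 gives 18100 nM.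

Compound 4 `COc1cc(-c2nnc(SCC(=O)C3CC3)n2-c2ccc(N(C)C)cc2)cc(OC)c1OC` has not yet been measured. It differs from compound 3 by cyclopropyl in place of naphthalen-2-yl on a carbonyl carbon. The same change, (cyclopropyl in place of naphthalen-2-yl on a carbonyl carbon), was made between two measured compounds, giving an at least 1.6-fold lower number from compound 1 to compound 2 (0.20 log units; that floor lies within the scatter); that step rests on (the limit of > 60000 nM in this assay, at which 1 of the 3 values shown sits), so its real size is uncertain. The place of the change is identical in both pairs. The two cores differ by dimethylamino in place of methoxy on an aromatic carbon, a change that gave an at least 3.3-fold lower number from compound 1 to compound 3 (0.52 log units; beyond the scatter). For compound 4 a step of a 1.2-fold lower number from compound 3 to compound 4 (0.08 log units; within the scatter) is expected, because an at least 1.6-fold lower number from compound 1 to compound 2 (0.20 log units; that floor lies within the scatter) suggests the change helps only slightly, if at all. Compound 4 is therefore estimated at 15000 nM in this assay, with a likely range from 6000 nM to 40000 nM.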

Compound 4, half-maximal inhibitory concentration: 45900 nM
The estimate for compound 4 lay 3.1-fold (0.49 log units) below the measured number; the whole stated range lies below it.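

In this assay, the change from naphthalen-2-yl to cyclopropyl gives a 2.5-fold higher number from compound 3 to compound 4 (0.40 log units; beyond the scatter), a loss of inhibition that does not match what the same change did on the core of compound 1: the same change on two cores in this assay, an at least 1.6-fold lower number (0.20 log units; that floor lies within the scatter) from compound 1 to compound 2 and a 2.5-fold higher number (0.40 log units; beyond the scatter) from compound 3 to compound 4, at least 4.0-fold (0.61 log units) apart, beyond the scatter of two such steps. The change from methoxy to dimethylamino also fails to carry over, giving a 1.2-fold higher number from compound 2 to compound 4 (0.09 log units; within the scatter) with cyclopropyl on the carbonyl, so the effect of each change here depends on the other group: the same change on two cores in this assay, an at least 3.3-fold lower number (0.52 log units; beyond the scatter) from compound 1 to compound 3 and a 1.2-fold higher number (0.09 log units; within the scatter) from compound 2 to compound 4, at least 4.0-fold (0.61 log units) apart, beyond the scatter of two such steps. Compound 1 gives > 60000 nM, a limit and not a number, so only a floor is known for these gaps, and two cores cannot show how the change behaves on others: the limit of > 60000 nM in this assay, at which 1 of the 4 values shown sits.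

As far as these compounds go, it remains open whether a phenyl ring or a longer chain on the carbonyl carbon would behave as cyclopropyl does here.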